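Antiproliferative series: methoxycarbonyl in place of nitro

The source may hold more compounds than are shown below. What is called first, only, known or untested is meant among the compounds shown, and "the series" means these compounds.

Three compounds of the shared core have numbers in a functional assay on MKN-45 cells (Homo sapiens) for antiproliferative activity, tested at 1 uM; a lower number here means less inhibition, a higher number more inhibition at the concentration tested (going by the name of the read-out). Compound 1 `Cc1nn(-c2ccccc2)c(Oc2ccc(Cl)cc2)c1/C=N/OCc1ccc(C(=O)OC(C)(C)C)cc1` gives -9.9%. Compound 2 `Cc1nn(C)c(Oc2ccc(Cl)cc2)c1/C=N/OCc1ccc([N+](=O)[O-])cc1` gives 24.6%, the highest of the three, and compound 3 `Cc1nn(C)c(Oc2ccccc2)c1/C=N/OCc1ccc([N+](=O)[O-])cc1` gives 18.3%. Among the measured compounds shown here, the one single-point step, a number 6.3 percentage points lower from compound 2 to compound 3 (within the scatter), lies within the scatter; compound 2 and compound 3 are therefore not separable on these numbers, while the gap from compound 2 down to compound 1 is beyond the scatter. Compound 1 and compound 2 differ in two places, so their values say nothing about either change alone.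

Compound 4 `COC(=O)c1ccc(CO/N=C/c2c(C)nn(C)c2Oc2ccc(Cl)cc2)cc1` is not yet measured. It differs from compound 2 in one place: methoxycarbonyl in place of nitro on an aromatic carbon. No measured step touches this position; the only step shown concerns the other aromatic ring. There is thus no basis for expecting a step beyond the scatter in this assay, and the step of a number 9.6 percentage points lower from compound 2 to compound 4 (within the scatter) is estimated as small. Compound 4 is expected to give about 15%, in a range from -5% to 35%.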

Compound 4, a percentage reported as inhibition, at one concentration (the size of the read-out at that concentration, not a potency): 26.1%
For compound 4 the middle estimate is 11.1 percentage points below the measured one; measured number inside the range.
By their numbers in this assay, from the lowest: compound 1; then compounds 3, 2 and 4 (each within the scatter of the next).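

In this assay, among the compounds shown here, methoxycarbonyl in place of nitro on an aromatic carbon, para to a large group, gives a number 1.5 percentage points higher from compound 2 to compound 4 (within the scatter), the first measured step at this position. On this pair, nitro is not needed for the inhibition seen with compound 2, since a group with one more heavy atom and the same count of hydrogen-bond acceptors cannot be told apart from it here. No measurement at hand bears on why the two groups read alike.

Going by these compounds, whether the number in this assay is higher, lower or level with groups of another kind at this position, such as an amine, a carboxylic acid or a longer chain, stays open. Compound 1 differs from compound 4 in two places, so the contribution of its ester group alone cannot be read.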